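The compounds below may be only part of what the source reports. "The series", "measured", "known", "first", "only" and "open" are said of these compounds alone.

Measured in an assay on BHK21 (C13) cells (Mesocricetus auratus) for inhibition of thymidine kinase, cytosolic (Cricetulus griseus), using Lineweaver-Burk analysis; a higher number here means a weaker inhibitor, a lower number a stronger inhibitor:
- compound 1 `N#Cc1cn([C@H]2C[C@H](O)[C@@H](CO)O2)c(=O)[nH]c1=O`: 220000 nM
- compound 2 `CCCCCCNC[C@H]1O[C@@H](n2cc(C)c(=O)[nH]c2=O)C[C@@H]1O`: 180000 nM

Compound 2 and compound 1 give numbers that lie within the usual scatter of each other, so neither can be placed above or below the other; both are weak inhibitors in this assay. Among the measured compounds shown here, no pair among the measured compounds differs in a single place, so no step size has been established.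

Compound 3 `Cc1cn([C@H]2C[C@H](O)[C@@H](CSCCO)O2)c(=O)[nH]c1=O` is not yet measured. It differs from compound 2 by (2-hydroxyethyl)sulfanyl in place of hexylamino on a saturated chain carbon bound to a saturated ring carbon. For the measured compounds named here, the hexylamino group of compound 2 gives no basis for a step of known size, and the two measured values are close to each other, so the expectation for compound 3 is a number in the same weak range, with no step beyond the scatter: an estimated 1.4-fold higher number from compound 2 to compound 3 (0.14 log units; within the scatter).

Compound 3 is therefore expected at 250000 nM, with a range of 80000 nM to 800000 nM.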

Compound 3, inhibition constant: 800000 nM
Compound 3: middle estimate off by 3.2-fold (0.51 log units), on the low side; low and high end bracket the measured number.
By their numbers in this assay, from the lowest: compounds 2 and 1 (each within the scatter of the next); then compound 3.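

Among the compounds shown here, at this saturated chain carbon bound to a saturated ring carbon, the read-out in this assay does respond to the substituent: (2-hydroxyethyl)sulfanyl in place of hexylamino gives the first step that lies beyond the scatter (a 4.4-fold higher number from compound 2 to compound 3 (0.65 log units; beyond the scatter)). The change is compound in nature, as 4 heavy atoms with sulfur and oxygen replace 7 heavy atoms with nitrogen, so this single step cannot be assigned to any one of these differences. No available data account for the step.

As far as these compounds go, whether the step follows the chain length, the sulfur or the terminal hydroxyl remains open; hexylsulfanyl or 2-hydroxyethylamino at this place would separate these differences. Also open, from the compounds shown here alone, is how a simple primary amine or a carboxylic acid on this carbon would compare with compound 2.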